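From carboxy to hydroxycarbamoyl on the shared core

The compounds below may be only part of what the source reports. "The series", "measured", "known", "first", "only" and "open" are said of these compounds alone.

Among the compounds with values here, in a functional assay on MDA-MB-231 cells (Homo sapiens) for antiproliferative activity, read by MTT assay, with a stated time of 72 h (a lower number here means a stronger inhibitor, a higher number a weaker inhibitor), compound 2 (`O=C(O)c1cccc(NCCOc2ccc3cc2COC/C=C/COCc2cccc(c2)-c2ccnc(n2)N3)c1`) gives 21400 nM and is the weaker of the two measured compounds, while compound 1 (`O=C(NO)c1ccc(NCCOc2ccc3cc2COC/C=C/COCc2cccc(c2)-c2ccnc(n2)N3)cc1`) gives 8690 nM as the only other number. Compound 3 (`O=C(NO)c1cccc(NCCOc2ccc3cc2COC/C=C/COCc2cccc(c2)-c2ccnc(n2)N3)c1`) has hydroxyamino in place of hydroxy on a carbonyl carbon and so turns carboxy to hydroxycarbamoyl. Within the data shown here, one measured step bears on this (a 2.5-fold higher number from compound 1 to compound 2 (0.39 log units; beyond the scatter)) and is modest, but it also changes the 4-(hydroxycarbamoyl)phenyl to 3-carboxyphenyl, so it is only a partial guide. The expected change runs the opposite way in this assay and is of similar size (a 2.1-fold lower number from compound 2 to compound 3 (0.33 log units; beyond the scatter)) as estimated here. For compound 3 the expected value is 10000 nM with 4500 nM to 22000 nM as its estimated range.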

Compound 3, half-maximal inhibitory concentration: > 50000 nM
Compound 3: a limit, no number; the forecaster's own chance of this, stated with the estimate: 3%; at least 5.0-fold (0.69 log units) between middle value and limit.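

In this assay compound 3 gives only a limit of the assay, not a number: the limit of > 50000 nM in this assay, at which 1 of the 3 values shown sits.

On the 3-substituted ring, hydroxyamino in place of hydroxy on the carbonyl carbon gives an at least 2.3-fold higher number from compound 2 to compound 3 (0.36 log units; beyond the scatter). With the hydroxycarbamoyl group kept, 3-(hydroxycarbamoyl)phenyl in place of 4-(hydroxycarbamoyl)phenyl gives an at least 5.7-fold higher number from compound 1 to compound 3 (0.75 log units; beyond the scatter), so the position of this group on the phenyl ring matters, which the earlier step, changing both group and position at once, could not show.

As far as these compounds go, whether a 4-carboxyphenyl group would give a number nearer compound 1 or compound 2 stays open. So does the effect of a primary amide or a methyl ester in this place.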